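Adding a Methyl to a Growth Inhibitor

The source may report more compounds than this note shows. Statements on the series, on what has been measured and on what is new or still open speak of the compounds shown alone.

In a functional assay on A549 cells (Homo sapiens) for inhibition, read by sulforhodamine B assay (on this read-out lower numbers stand for stronger inhibition of growth and higher numbers for weaker inhibition of growth), compound 1 (`c1ccc(-c2ccc(-c3ccc(-c4nc5ccccc5[nH]4)cc3)cc2)cc1`) gives 41200 nM. Compound 2 (`COc1ccc(-c2ccc(-c3ccc(-c4nc5ccccc5[nH]4)cc3)cc2)cc1`) gives 38100 nM, within the scatter of that number, while compound 3 (`Oc1cccc2[nH]c(-c3ccc(-c4ccc(-c5ccccc5)cc4)cc3)nc12`) gives a clearly lower 8320 nM. Compound 4 (`Cc1ccc2[nH]c(-c3ccc(-c4ccc(-c5ccccc5)cc4)cc3)nc2c1`) is the next to consider, with this change from the core of compound 1: methyl in place of hydrogen on an aromatic carbon. Among the measured compounds shown here, two measured steps bear on it. Methoxy in place of hydrogen gave a 1.1-fold lower number from compound 1 to compound 2 (0.03 log units; within the scatter), and hydroxy in place of hydrogen gave a 5.0-fold lower number from compound 1 to compound 3 (0.69 log units; beyond the scatter). Neither is an exact guide to methyl, so only a slight fall in this assay is expected, possibly none beyond the scatter. The expected step is a 1.5-fold lower number from compound 1 to compound 4 (0.17 log units; within the scatter). For compound 4 the estimate is 28000 nM, with an expected range of 10000 nM to 50000 nM.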

Compound 4, concentration for 50% growth inhibition: 3630 nM
Estimate against measurement, compound 4: 7.7-fold (0.89 log units) above; measured number below the stated range.
By their numbers in this assay, from the lowest: compound 4; then compound 3; then compounds 2 and 1 (each within the scatter of the next).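

In this assay a single methyl on the six-membered aromatic ring of carbon only, part of the fused system, gives an 11-fold lower number from compound 1 to compound 4 (1.05 log units; beyond the scatter) and this large step lies beyond the scatter. So one added carbon, with 0 hydrogen-bond donors and 0 hydrogen-bond acceptors, can change growth inhibition strongly here, more than the methoxy and hydroxy steps suggested. Nothing measured here explains the size of this step.

From the compounds shown here alone, whether a longer chain such as ethyl, an amine or a carboxylic acid would act like methyl in this place stays open. So does whether methyl on another carbon of that ring would give a similar step.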